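This account rests on a few compounds, and the source may have more. Where it says the series, first, only, none or still open, it means among the compounds named here.

Measured so far in a functional assay on the whole organism with Mus musculus as the target; on this read-out lower numbers stand for an effect already at smaller amounts and higher numbers for an effect only at larger amounts of compound:
- Compound 1 `CCCc1ccc(C2c3c(C)c(N)c(C)c(C)c3OC2(C)C)cc1`: > 50 mg/kg, a limit of the assay and not a number
- Compound 2 `CCCCCc1ccc(C2c3c(C)c(N)c(C)c(C)c3OC2(C)C)cc1`: 42.2 mg/kg
- Compound 3 `Cc1c(C)c2c(c(C)c1N)C(c1ccc(F)cc1)C(C)(C)O2`: 26.7 mg/kg

Compound 3 is not clearly set apart from its neighbours. The gap to the nearest real number is a 1.6-fold lower number from compound 2 to compound 3 (0.20 log units; within the scatter). Against the limit, the comparison gives only a floor, an at least 1.8-fold lower number from compound 1 to compound 3 (0.27 log units; that floor lies within the scatter).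

Compound 4 `Cc1c(C)c2c(c(C)c1N)C(C(C)C)C(C)(C)O2` carries isopropyl in place of 4-fluorophenyl on a saturated ring carbon. Among the compounds with values here, no measured step touches that ring carbon, so the evidence is indirect. The steps available change only the group on an aromatic carbon: an at least 1.1-fold lower number from compound 1 to compound 2 (0.07 log units; that floor lies within the scatter), together with the two above. None of them goes beyond the scatter, although pentyl, propyl and fluoro are quite different groups. Losing the whole aromatic ring is untested, so the uncertainty is wide.

In this assay, no step beyond the scatter is therefore expected, and a result reported only as a limit remains possible. The estimated step is a 1.1-fold higher number from compound 3 to compound 4 (0.05 log units; within the scatter). For compound 4 the estimated value is 30 mg/kg, with an expected range from 12 mg/kg to 75 mg/kg.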

Compound 4, dose for 50% inhibition: 14 mg/kg
Compound 4: the middle estimate sits 2.1-fold (0.33 log units) above what was measured, within the range that was stated.
By their numbers in this assay, from the lowest: compounds 4, 3 and 2 (each within the scatter of the next, the first and the last beyond it). At a limit, above all of these: compound 1.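

Within the data shown here, this is the first change at the saturated ring carbon, and it removes a whole six-membered aromatic ring, leaving an open-chain isopropyl group in its place. In this assay, the result is a 1.9-fold lower number from compound 3 to compound 4 (0.28 log units; within the scatter), so compound 4 shows that the effect in this assay does not depend on an aromatic ring at this carbon, and the core tolerates quite different groups here. Nothing among the measurements shown explains why these two groups give values so close together.

Among these compounds, with only this one pair at the saturated ring carbon, no trend in group size or shape can be drawn from it. On these data alone, it remains open how a methyl group, a cyclohexyl ring, a longer chain such as pentyl, or a chain ending in an amine or a carboxylic acid would behave at this carbon.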